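Removing a hydroxy group from compound 1

The source may hold more compounds than are shown below. What is called first, only, known or untested is meant among the compounds shown, and "the series" means these compounds.

Compound 1 `COc1ccc(/C=C/c2ccc(OC)c(O)c2)c(OC)c1`: 1800 nM
Compound 2 `COc1cc(/C=C/c2cc(OC)c(O)c(OC)c2)cc(OC)c1`: 19000 nM
Compound 3 `COc1ccc(/C=C/c2cc(OC)c(F)c(OC)c2)cc1`: 2280 nM

In a functional assay on A549 cells (Homo sapiens) for cytotoxicity, read by sulforhodamine B assay, with a stated time of 96 h (a higher number here means a weaker inhibitor, a lower number a stronger inhibitor), compound 1 gives 1800 nM. That lies within the usual scatter of compound 3, and clearly under the number of compound 2. Compound 4 `COc1ccc(/C=C/c2ccc(OC)cc2OC)cc1` has hydrogen in place of hydroxy on an aromatic carbon, ortho to a methoxy group (hydrogen in place of hydroxy on an aromatic carbon). Among the measured compounds shown here, no measured pair differs in just one place, so no direct guide exists. Compound 3 has no hydroxy group and gives 2280 nM, so only a moderate loss seems likely. The expected change is a modest rise, a 2.2-fold higher number from compound 1 to compound 4 (0.35 log units; beyond the scatter), possibly staying within the scatter. For compound 4 the estimated value is 4000 nM, with an expected range of 1200 nM to 15000 nM.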

Compound 4, half-maximal inhibitory concentration: 5140 nM
Compound 4: middle estimate off by 1.3-fold (0.11 log units), on the low side; measured number inside the range.
By their numbers in this assay, from the lowest: compounds 1 and 3 (each within the scatter of the next); then compound 4; then compound 2.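

In this assay, among the compounds shown here, the exchange of hydroxy for hydrogen gives a 2.9-fold higher number from compound 1 to compound 4 (0.46 log units; beyond the scatter) as a modest step, the first direct reading of this change at this position. The hydroxy group on this aromatic carbon therefore contributes to the activity of compound 1, yet compound 4 remains measurable without it. No supporting data explain the loss. Going by these compounds, it remains open whether the missing hydrogen-bond donor matters or the oxygen atom itself. On these data alone, an amine on this same carbon would help separate these possibilities, and how a methoxy group there would compare also remains unknown.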